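Trimming a Methoxy Group from Compound 2

This account rests on a few compounds, and the source may have more. Where it says the series, first, only, none or still open, it means among the compounds named here.

Of the compounds shown here, three built on one shared core have been tested in a functional assay on DU-145 cells (Homo sapiens) for antiproliferative activity, read by MTT assay, with a stated time of 24 h; on this read-out lower numbers stand for stronger inhibition and higher numbers for weaker inhibition. Compound 1 `COc1ccc(-c2cc(/C=C/C(=O)c3cc(OC)c(OC)c(OC)c3)nc3cc(-c4ccccc4)nn23)cc1OC` gives 8300 nM, compound 2 `COc1ccc(C(=O)/C=C/c2cc(-c3ccc(OC)c(OC)c3)n3nc(-c4ccccc4)cc3n2)cc1` gives 14600 nM, and compound 3 `COc1ccc(/C=C/C(=O)c2cc(-c3ccc(OC)c(OC)c3)n3nc(-c4ccccc4)cc3n2)cc1` gives 14900 nM. Among these three numbers compound 2 holds the second highest; compound 3 is its nearest neighbour and compound 1 its furthest, yet both gaps stay inside the scatter, so the three compounds cannot be told apart. The step of a 1.8-fold higher number from compound 1 to compound 2 (0.25 log units; within the scatter) swaps 3,4,5-trimethoxyphenyl for 4-methoxyphenyl on a carbonyl carbon, and the step of a 1.0-fold higher number from compound 2 to compound 3 (0.01 log units; within the scatter) places (2-(4-methoxyphenyl)ethenyl)carbonyl in place of 2-((4-methoxyphenyl)carbonyl)ethenyl on an aromatic carbon; neither moves the read-out beyond the scatter.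

Compound 4 `COc1ccc(C(=O)/C=C/c2cc(-c3ccc(OC)cc3)n3nc(-c4ccccc4)cc3n2)cc1` is the next step from compound 2. The change is hydrogen in place of methoxy on an aromatic carbon, which read one bond further out is 3,4-dimethoxyphenyl to 4-methoxyphenyl. Going by the values given here, no measured pair removes a methoxy at exactly this place, but the larger loss of methoxy groups in the step of a 1.8-fold higher number from compound 1 to compound 2 (0.25 log units; within the scatter) left the number within the scatter, which suggests methoxy groups count for little here. The expected step of a 1.0-fold higher number from compound 2 to compound 4 (0.01 log units; within the scatter) is therefore small, in neither direction beyond the scatter. Compound 4 is estimated at 15000 nM, with a likely range from 7000 nM to 32000 nM.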

Compound 4, half-maximal inhibitory concentration: 8500 nM
Estimate against measurement, compound 4: 1.8-fold (0.25 log units) above, within the range that was stated.
By their numbers in this assay, from the lowest: compounds 1, 4, 2 and 3 (each within the scatter of the next).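

In this assay, going by these compounds alone, turning 3,4-dimethoxyphenyl into 4-methoxyphenyl gives a 1.7-fold lower number from compound 2 to compound 4 (0.23 log units; within the scatter), and this is the first measured test of this place: an aromatic carbon ortho to a methoxy group and meta to a large group. The earlier step of a 1.8-fold higher number from compound 1 to compound 2 (0.25 log units; within the scatter) removed methoxy groups from the ring on the carbonyl carbon, whereas this one removes a single methoxy from a different ring, and neither step moves the number beyond the scatter, so among these compounds the methoxy at this place can give way to hydrogen with no change that can be told from repeat-measurement noise. Nothing available explains this outcome, and no measurement beyond the antiproliferative numbers bears on it.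

The compounds shown leave open what a group other than hydrogen would do at this place, such as an ethoxy group, an amine or a carboxylic acid. They also leave open what happens to the read-out if the remaining methoxy group on this ring, still present in compound 4 , is replaced by hydrogen or by a fluorine atom.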